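Replacing the nitro of compound 2 with fluoro

A few compounds are considered here, and "the series" means these few. Any claim that something is new, unique, unknown or untested is made for them only; others in the source may bear on it.

In a functional assay on T98G cells (Homo sapiens) for cytotoxicity, read by MTT assay, with a stated time of 48 h (on this read-out lower numbers stand for stronger inhibition and higher numbers for weaker inhibition), the measured compounds are:
Compound 1 `C/C(=N/NC(=S)Nc1ccc(Cl)cc1)c1ccccn1` gives 5.9 nM
Compound 2 `C/C(=N/NC(=S)Nc1ccc([N+](=O)[O-])cc1)c1ccccn1` gives 140 nM

Compound 2 at 140 nM holds the higher of the two numbers in this assay and is thus the weaker of the pair. Compound 3 `C/C(=N/NC(=S)Nc1ccc(F)cc1)c1ccccn1` differs from it in one place, and the change reads fluoro in place of nitro on an aromatic carbon. Going by the values given here, only one measured step bears on this, namely a 24-fold higher number from compound 1 to compound 2 (1.38 log units; beyond the scatter) and there too the nitro group is what separates the two compounds, with chloro standing in its place. That step is large. Among the compounds with values here, no fluoro compound has been measured, so chloro serves only as a guide, and compound 1 at 5.9 nM shows the one case without the nitro group. A large step toward a lower number is therefore expected in this assay for this change, though perhaps not quite the whole way. The expected change is a 12-fold lower number from compound 2 to compound 3 (1.07 log units; beyond the scatter) in this estimate. For compound 3 the estimated value is 12 nM (expected range 3 nM to 60 nM).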

Compound 3, half-maximal inhibitory concentration: 17 nM
Estimate against measurement, compound 3: 1.4-fold (0.15 log units) below, within the range that was stated.
By their numbers in this assay, from the lowest: compound 1; then compound 3; then compound 2.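

In this assay, fluoro in place of nitro on an aromatic carbon gives an 8.2-fold lower number from compound 2 to compound 3 (0.92 log units; beyond the scatter), so a second group, after chloro, reads well below nitro at this place on the shared core. The two replacements are not interchangeable, however, since fluoro in place of chloro gives a 2.9-fold higher number from compound 1 to compound 3 (0.46 log units; beyond the scatter), and this gap is beyond the usual scatter, which shows that this position also separates one halogen from the other. Nothing available explains why these three groups fall in this order.

The compounds shown leave open whether an amine, a methoxy group or a carboxylic acid at this place would read closer to the halogens or closer to nitro, and whether bromo would continue the difference seen between chloro and fluoro. They also leave open whether the same order would hold with these groups on another carbon of the ring, or in cells other than the T98G line.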